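This account rests on a few compounds, and the source may have more. Where it says the series, first, only, none or still open, it means among the compounds named here.

Compound 1 (`COc1ccc(-c2cc(F)c3ncc(Cc4ccc5ncccc5c4)n3c2)cc1F`) gives 407 nM in a functional assay on EBC-1 cells (Homo sapiens) for antiproliferative activity, with a stated time of 72 h; a higher number here means a weaker inhibitor, a lower number a stronger inhibitor
Compound 2 (`CN(C)CCNC(=O)c1ccc(-c2cc(F)c3ncc(Cc4ccc5ncccc5c4)n3c2)cc1F`) gives 49 nM in this assay

Compound 2 stands lowest of the two at 49 nM and so is the stronger inhibitor here. Compound 3 (`O=C(NCC1CCCCN1)c1ccc(-c2cc(F)c3ncc(Cc4ccc5ncccc5c4)n3c2)cc1F`) keeps the shared core and the amide but alters the end of the chain (piperidin-2-yl in place of (dimethylamino)methyl on a saturated chain carbon bound to an amide-type nitrogen), so that 2-(dimethylamino)ethyl becomes (piperidin-2-yl)methyl. Going by the values given here, only one measured step bears on this (an 8.3-fold lower number from compound 1 to compound 2 (0.92 log units; beyond the scatter)). It brought in the whole (2-(dimethylamino)ethyl)carbamoyl group in place of methoxy, and compound 3 keeps the carbamoyl, so no step beyond the scatter is expected in this assay in either direction. Among the compounds with values here, no measured pair varies the chain end alone, which leaves this expectation loose. The estimate means a 1.2-fold higher number from compound 2 to compound 3 (0.09 log units; within the scatter) as the expected step. Compound 3 is estimated at 60 nM with an expected range from 20 nM to 180 nM in this test.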

Compound 3, half-maximal inhibitory concentration: 277 nM
For compound 3 the middle estimate is 4.6-fold (0.66 log units) below the measured one, and the stated range ends below it.
By their numbers in this assay, from the lowest: compound 2; then compounds 3 and 1 (each within the scatter of the next).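

The end of the chain matters in this assay: with the carbamoyl kept, piperidin-2-yl in place of (dimethylamino)methyl gives a 5.7-fold higher number from compound 2 to compound 3 (0.75 log units; beyond the scatter), so this place on the chain does not accept every amine-bearing end equally. The amide alone therefore does not account for the gain seen with compound 2, as ((piperidin-2-yl)methyl)carbamoyl in place of methoxy gives just a 1.5-fold lower number from compound 1 to compound 3 (0.17 log units; within the scatter), which leaves the chain-bearing compound 3 no clear advantage over the methoxy compound 1. No evidence here explains why these two chain ends differ.

The compounds shown leave open which part of the change counts: the six-membered ring or the added hydrogen-bond donor. A 1-methylpiperidin-2-yl end would separate the two, while a morpholine end or a longer chain would test how far the result extends.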